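This account rests on a few compounds, and the source may have more. Where it says the series, first, only, none or still open, it means among the compounds named here.

In a functional assay on MCF7 cells (Homo sapiens) for antiproliferative activity, read by sulforhodamine B assay, with a stated time of 48 h (a higher number here means a weaker inhibitor, a lower number a stronger inhibitor), compound 1 (`COc1cc(C=C(C(=O)/C=C/c2cccc(OC)c2OC)C(=O)/C=C/c2cccc(OC)c2OC)ccc1O`) gives 480 nM and compound 2 (`COc1cc(OC)c(C=C(C(=O)/C=C/c2cccc(OC)c2OC)C(=O)/C=C/c2cccc(OC)c2OC)c(OC)c1`) gives 720 nM. Within the data shown here, these are the only two measurements so far. The step between them is a 1.5-fold higher number from compound 1 to compound 2 (0.18 log units; within the scatter), so compound 2 stands level with compound 1 rather than clearly apart from it. Compound 3 (`COc1cccc(C=C(C(=O)/C=C/c2cccc(OC)c2OC)C(=O)/C=C/c2cccc(OC)c2OC)c1OC`) keeps the shared core and changes one group on a double-bonded chain carbon bound to a double-bonded chain carbon: 2,3-dimethoxyphenyl in place of 2,4,6-trimethoxyphenyl on a double-bonded chain carbon bound to a double-bonded chain carbon. Among the measured compounds shown here, only one measured step bears on this change, since it swaps a group at that same place, and that step, a 1.5-fold higher number from compound 1 to compound 2 (0.18 log units; within the scatter), stayed within the scatter. One step is thin evidence, but it gives no reason to expect a real shift in this assay in either direction. The expected change is a 1.2-fold lower number from compound 2 to compound 3 (0.08 log units; within the scatter). For compound 3 the estimated value is 600 nM, with an expected range from 250 nM to 1400 nM.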

Compound 3, half-maximal inhibitory concentration: 520 nM
Beside the measured number, compound 3's estimate is 1.2-fold (0.06 log units) above it; measured number inside the range.
By their numbers in this assay, from the lowest: compounds 1, 3 and 2 (each within the scatter of the next).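

In this assay, a third substituted phenyl group on a double-bonded chain carbon bound to a double-bonded chain carbon again stays within the scatter, both against 2,4,6-trimethoxyphenyl (a 1.4-fold lower number from compound 2 to compound 3 (0.14 log units; within the scatter)) and against 4-hydroxy-3-methoxyphenyl (a 1.1-fold higher number from compound 1 to compound 3 (0.03 log units; within the scatter)). Compounds 1, 2 and 3 therefore stand level, so this position shows no real preference among these three groups, with or without the hydroxy group of compound 1. Nothing measured here explains this lack of difference.

From the compounds shown here alone, whether the position stays this undemanding for a group of another kind, such as a phenyl ring carrying an amine or a carboxylic acid, remains open. Going by these compounds, the rest of the shared core is the same in all three compounds, so the effect of changing it also remains unknown.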